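The source may report more compounds than this note shows. Statements on the series, on what has been measured and on what is new or still open speak of the compounds shown alone.

Compound 1 `O=C(/C=C/c1ccc(O)cc1)c1c(O)cccc1OCc1ccccc1`: > 30000 nM
Compound 2 `CC(C)CCOc1cccc(O)c1C(=O)/C=C/c1ccc(O)cc1`: 12100 nM
Compound 3 `CCCCOc1cccc(O)c1C(=O)/C=C/c1ccc(O)cc1`: not yet measured

Of the compounds shown here, two have been tested so far in a functional assay on NCI-H23 cells (Homo sapiens) for antiproliferative activity, read by sulforhodamine B assay; a lower number here means a stronger inhibitor of growth, a higher number a weaker inhibitor of growth. For compound 1 the reading of > 30000 nM is a limit of the assay rather than a number, namely (the limit of > 30000 nM in this assay, at which 1 of the 2 values shown sits). Compound 2 gives 12100 nM, the only true number among the two results shown. Among the compounds with values here, the one measured step, an at least 2.4-fold lower number from compound 1 to compound 2 (0.39 log units; beyond the scatter), exchanged phenyl for isobutyl on a saturated chain carbon bound to an oxygen on an aromatic ring. Compound 3 keeps the whole core of compound 2 and differs from it only in that chain: hydrogen in place of methyl on a saturated chain carbon bound to two saturated chain carbons. Within the data shown here, this is a far smaller change than the phenyl-to-isobutyl swap, so the one measured step does not bear on it directly, and no other step exists. For compound 3 the expected result in this assay is therefore a step of a 1.1-fold higher number from compound 2 to compound 3 (0.03 log units; within the scatter), not beyond the scatter in either direction, with an estimate of 13000 nM and a range from 5000 nM to 30000 nM.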

Compound 3, concentration for 50% growth inhibition: > 30000 nM
Compound 3 ended at the assay's limit; the forecaster's own chance of this, stated with the estimate: 20%; middle value at least 2.3-fold (0.36 log units) away from the limit.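

In this assay, taking one methyl off the saturated chain carbon bound to two saturated chain carbons turns isopentyl into butyl and gives an at least 2.4-fold higher number from compound 2 to compound 3 (0.39 log units; beyond the scatter). The earlier compounds shown here showed only that exchanging a phenyl for an isobutyl at the end of this chain could matter, whereas this result shows that even the loss of a single carbon at the branch point can be seen in growth inhibition. Compound 3 reads > 30000 nM, a limit of the assay and not a number, so the true size of this step stays unknown, and compound 2 remains the only one of the three with a true number: the limit of > 30000 nM in this assay, at which 2 of the 3 values shown sit.

The step between compound 1 and compound 3 cannot be read, as both ends of it are limits. Isopentyl and butyl differ in both branching and chain length, so the compounds shown cannot separate the two, and a straight pentyl chain would bear on that question, while a longer branched chain or a chain ending in an amine leaves open how far the number could fall.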